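Swapping the aryl amide cap on a sulfonylurea scaffold

This account rests on a few compounds, and the source may have more. Where it says the series, first, only, none or still open, it means among the compounds named here.

Of the compounds shown here, three sharing a piperidine-linked sulfonylurea core have been tested in a functional assay on the whole organism (blood) with Rattus norvegicus as the target, with stated times of 24 h and 1 h, at a dose of 15 mg/kg by the intraperitoneal route; on this read-out lower numbers stand for a weaker effect and higher numbers for a stronger effect at the one dose given. Compound 1 `O=C(NC[C@@H]1C[C@@H]2C=C[C@@H]1C2)NS(=O)(=O)N1CCC(CCNC(=O)c2cnsc2)CC1` gives 14%. Compound 2 `Cc1ncsc1C(=O)NCCC1CCN(S(=O)(=O)NC(=O)NC[C@@H]2C[C@@H]3C=C[C@@H]2C3)CC1` gives 25%, which places it second highest among the three numbers, with compound 3 `COc1ncccc1C(=O)NCCC1CCN(S(=O)(=O)NC(=O)NC2CCCCC2)CC1` giving 35%, a difference within the scatter. Among the measured compounds shown here, the single step that differs in one place, a number 11 percentage points higher from compound 1 to compound 2 (beyond the scatter), came with a heteroaryl swap on the carbonyl carbon.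

Compound 4 `COc1ccc(C(=O)NCCC2CCN(S(=O)(=O)NC(=O)NC[C@@H]3C[C@@H]4C=C[C@@H]3C4)CC2)cn1` is so far unmeasured. For the measured compounds named here, it differs from compound 2 as follows: 6-methoxypyridin-3-yl in place of 4-methyl-1,3-thiazol-5-yl on a carbonyl carbon The only measured step, from compound 1 to compound 2, also exchanged the aromatic ring on that carbonyl carbon and was modest in size. Going by the values given here, no measured step exchanges a five-membered for a six-membered aromatic ring, so the expectation for this assay rests on that modest precedent and on the nearby number of compound 3, which also carries a six-membered aromatic ring there. Compound 4 is therefore expected to show a number 5 percentage points higher from compound 2 to compound 4 (within the scatter), a change that may well lie within the scatter, giving an estimated 30% with a range from 12% to 50%.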

Compound 4, a percentage reported as activity, at one dose (the size of the read-out at that dose, not a potency): 32%
The estimate for compound 4 lay 2 percentage points below the measured number; low and high end bracket the measured number.
By their numbers in this assay, from the lowest: compound 1; then compounds 2, 4 and 3 (each within the scatter of the next).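

The new result shows that a six-membered aromatic ring is accepted on this carbonyl carbon: in this assay the change to 6-methoxypyridin-3-yl gives a number 7 percentage points higher from compound 2 to compound 4 (within the scatter) and so does not separate the two rings. Measured against the 1,2-thiazol-4-yl group, the same ring gives a number 18 percentage points higher from compound 1 to compound 4 (beyond the scatter) and is the second replacement of that group to lie beyond the scatter. At this position, the step away from 1,2-thiazol-4-yl therefore holds for both a five-membered and a six-membered aromatic ring.

On these data alone, whether a plain phenyl ring, or a pyridine carrying an amine or a carboxylic acid, would fit the same picture remains open. A reading at one dose also leaves the potency of these compounds unknown.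

No evidence at hand bears on the reason for these differences.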